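This account rests on a few compounds, and the source may have more. Where it says the series, first, only, none or still open, it means among the compounds named here.

Two compounds share one core and differ only in the group on a saturated chain carbon bound to a saturated ring carbon. Compound 1 `CCN1CCN(C[C@H]2CN(c3ccc(-n4cc(-c5ccccn5)cn4)c(F)c3)C(=O)O2)CC1` gives 706000 nM in a physicochemical assay for solubility, read by HPLC, with a stated time of 24 h; a higher number here means a more soluble compound, a lower number a less soluble compound. For the measured compounds named here, compound 2 `O=C1O[C@@H](Cn2ccnc2)CN1c1ccc(-n2cc(-c3ccccn3)cn2)c(F)c1` gives 12300 nM in this assay and stands lowest of the two numbers, the single step being a 57-fold lower number from compound 1 to compound 2 (1.76 log units; beyond the scatter). Compound 3 `O=C1O[C@@H](CSc2cccs2)CN1c1ccc(-n2cc(-c3ccccn3)cn2)c(F)c1` is not yet measured. Its change from compound 2 is (thiophen-2-yl)sulfanyl in place of 1H-imidazol-1-yl on a saturated chain carbon bound to a saturated ring carbon. Going by the values given here, the only measured step sits at the same place, but neither of its two groups is the group that enters here, so it gives direction only in the loosest sense: it shows that swapping the group at this position can move this assay by a large amount. Compound 3 is expected to land somewhat lower, at an estimated 3000 nM, with a range from 500 nM to 15000 nM, so that the step from compound 2 to compound 3 is expected to be a 4.1-fold lower number from compound 2 to compound 3 (0.61 log units; beyond the scatter).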

Compound 3, solubility: 8500 nM
For compound 3 the middle estimate is 2.8-fold (0.45 log units) below the measured one; measured number inside the range.
By their numbers in this assay, from the lowest: compounds 3 and 2 (each within the scatter of the next); then compound 1.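

In this assay the exchange of 1H-imidazol-1-yl for (thiophen-2-yl)sulfanyl gives a 1.4-fold lower number from compound 2 to compound 3 (0.16 log units; within the scatter) and so, at this place, these two groups cannot be told apart, even though the entering group carries sulfur and no nitrogen. Measured against 4-ethylpiperazin-1-yl, the entering group gives an 83-fold lower number from compound 1 to compound 3 (1.92 log units; beyond the scatter) and so, among these three compounds, the group of compound 1 alone stands apart, with no compound going against that. No information is given that accounts for these numbers.

Still open, as far as these compounds go, is which part of 4-ethylpiperazin-1-yl goes with the high number of compound 1, the ring or its ethyl group. A plain piperazine, a morpholine or a short chain ending in a carboxylic acid at this place could begin to separate those possibilities.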